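A few compounds are considered here, and "the series" means these few. Any claim that something is new, unique, unknown or untested is made for them only; others in the source may bear on it.

Working notes on the series. Of the compounds shown here, two have numbers so far in an assay on isolated protein for inhibition of Rho-associated protein kinase 2 (Homo sapiens); a higher number here means a weaker inhibitor, a lower number a stronger inhibitor. Compound 1 `COc1cc(NC(=O)C2COc3ccccc3C2)c(F)cc1-c1cn[nH]c1` gives 17 nM in this assay. Compound 2 `O=C(O)c1ccc2c(c1)CC(C(=O)Nc1ccc(-c3cn[nH]c3)cc1)CO2` carries a carboxy group on its core and gives 30 nM in this assay. Compound 2 stands at the higher of the two numbers, but its gap to compound 1 is within the scatter, so the two are read as equivalent on the present data. Among the measured compounds shown here, no two measured compounds differ in only one place, so no single-change step has been seen yet.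

Compound 3 `CN(C)C(=O)c1ccc2c(c1)CC(C(=O)Nc1ccc(-c3cn[nH]c3)cc1)CO2` is the next entry for this assay. It differs from compound 2 in one place: dimethylamino in place of hydroxy on a carbonyl carbon. For the measured compounds named here, nothing so far speaks to this kind of change, and compound 2 and compound 1, which differ in several places, sit within the scatter of each other. The working expectation is a step from compound 2 to compound 3 of a 1.3-fold higher number from compound 2 to compound 3 (0.12 log units; within the scatter), a small shift not clearly beyond the scatter in either direction. Compound 3 is accordingly estimated at 40 nM in this assay, with a range of 10 nM to 160 nM.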

Compound 3, half-maximal inhibitory concentration: 86 nM
Beside the measured number, compound 3's estimate is 2.2-fold (0.33 log units) below it; the measured number falls inside the stated range.
By their numbers in this assay, from the lowest: compounds 1 and 2 (each within the scatter of the next); then compound 3.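

Among the compounds shown here, the first single-change step sits on a carbonyl carbon whose other neighbour is an aromatic carbon. In this assay, dimethylamino in place of hydroxy gives a 2.9-fold higher number from compound 2 to compound 3 (0.46 log units; beyond the scatter) and so, unlike the gap between the two earlier compounds, carboxy to dimethylcarbamoyl registers as a real though modest change. The exchange removes the hydrogen-bond donor of the hydroxy and brings three heavy atoms in place of one, yet compound 3 still gives 86 nM and inhibition is not lost at this place; no measured evidence bears on what lies behind the step.

The compounds shown leave open whether the step follows the missing donor or the added carbons, a question that a primary carboxamide, which keeps amide hydrogens, or a methyl ester, which has none and adds a single carbon, would help to separate at the same carbonyl carbon. Also open, from the compounds shown here alone, is whether dimethylcarbamoyl in place of carboxy would give a step of similar size on a different core, such as the core of compound 1.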